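This account rests on a few compounds, and the source may have more. Where it says the series, first, only, none or still open, it means among the compounds named here.

In a physicochemical assay for solubility, in simulated intestinal fluid (a higher number here means a more soluble compound, a lower number a less soluble compound), the three measured compounds sit at the high end of the scale. Compound 1 `C[C@@H]1CN(c2sc(C(F)(F)F)nc2-c2nc3cc(OCCO)ccc3[nH]2)CCN1C(=O)Cn1cnc2cccnc21` gives 549 ug/mL. Compound 2 `C[C@@H]1CN(c2sc(C(F)(F)F)nc2-c2nc3ccccc3[nH]2)CCN1C(=O)Cn1cccn1` gives 734 ug/mL. Compound 3 `Cc1nc(C)n(CC(=O)N2CCN(c3sc(C(F)(F)F)nc3-c3nc4ccc(C5CCOCC5)cc4[nH]3)C[C@H]2C)n1` is reported only as a limit of the assay, > 1000 ug/mL; this is the limit of > 1000 ug/mL in this assay, at which 1 of the 3 values shown sits, so the true value of compound 3 is not a number but lies beyond what the measurement resolves. Going by the values given here, no step between two measured compounds that differ in one place is available, so nothing can be read from the set about how a single structural change moves this assay.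

Among the compounds with values here, compound 4 `Cc1nc(C)n(CC(=O)N2CCN(c3sc(C(F)(F)F)nc3-c3nc4ccc(C5CCN(C)CC5)cc4[nH]3)C[C@H]2C)n1` is the one compound not yet measured. It differs from compound 3 in a single place: 1-methylpiperidin-4-yl in place of oxan-4-yl on an aromatic carbon. The two groups are both six-membered non-aromatic rings with one hetero atom and one hydrogen-bond acceptor, and neither carries a net charge.

Within the data shown here, with no measured step to lean on, the step in this assay from compound 3 to compound 4 is expected to be none beyond the scatter, a number no higher from compound 3 to compound 4 (the limit leaves the size open), since compound 3 already sits at the limit and nothing in the remaining compounds points the other way. Compound 4 is therefore expected to come out at 1000 ug/mL, within a range from 500 ug/mL to 1000 ug/mL, most likely again reported as a limit.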

Compound 4, solubility: > 1020 ug/mL
Compound 4 ended at the assay's limit; the forecaster's own chance of this, stated with the estimate: 75%; middle value at least 1.0-fold (0.00 log units) from the limit.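

In this assay compound 3 gives > 1000 ug/mL, which is a limit and not a number. Compound 4 gives > 1020 ug/mL, also a limit, so no step can be read between these two compounds. The compounds shown leave open whether 1-methylpiperidin-4-yl in place of oxan-4-yl on an aromatic carbon moves this assay at all, and in which direction.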